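Three Sulfonamides at the Cytotoxicity Limit, a Fourth Awaited

This account rests on a few compounds, and the source may have more. Where it says the series, first, only, none or still open, it means among the compounds named here.

Compound 1, `CC1CCN(C2CCN(S(=O)(=O)c3ccccc3Br)CC2)CC1`. In an ADME assay on HCT-116 cells (Homo sapiens) for cytotoxicity, read by CellTiter-Glo, with a stated time of 72 h (on this read-out lower numbers stand for stronger inhibition and higher numbers for weaker inhibition), compound 1 gives > 5000 nM, which is a limit of the assay and not a number.
Compound 2, `CC1CCN(C2CCN(S(=O)(=O)c3ccccc3-c3ccccc3)CC2)CC1`. In this assay compound 2 gives > 5000 nM, again a limit rather than a number.
Compound 3, `CC1CCN(C2CCN(S(=O)(=O)c3cccc(Br)c3)CC2)CC1`. In this assay compound 3 gives > 5000 nM, also a limit and not a number.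

The three compounds share one core and differ only in the aryl group on the sulfonyl sulfur. From compound 1 to compound 2 the change is phenyl in place of bromo on an aromatic carbon, and the step it made is a step that the two limits leave unreadable from compound 1 to compound 2. From compound 1 to compound 3 the two cores differ as 3-bromophenyl in place of 2-bromophenyl on a sulfonyl sulfur, with the step that the two limits leave unreadable from compound 1 to compound 3. Nothing more can be drawn from these three values than the limit of > 5000 nM in this assay, at which 3 of the 3 values shown sit.

Compound 4, `CC1CCN(C2CCN(S(=O)(=O)c3cccc(-c4ccccc4)c3)CC2)CC1`, has not yet been measured. It differs from compound 3 by phenyl in place of bromo on an aromatic carbon. Within the data shown here, this is the same kind of change as the one from compound 1 to compound 2, not the same: in compound 2 the phenyl enters ortho to a large group, whereas in compound 4 it enters meta to a large group.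

In this assay the expected step is a step that the limit leaves unreadable from compound 3 to compound 4, which rests on the unreadable step that the two limits leave unreadable from compound 1 to compound 2 and on the fact that compound 3 itself gives only a limit, > 5000 nM. This expectation is shaped because of the limit of > 5000 nM in this assay, at which 3 of the 3 values shown sit. Compound 4 is therefore estimated at about 8000 nM, with the expected range running from 3000 nM to 30000 nM, and most likely reported as a limit once more.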

Compound 4, half-maximal inhibitory concentration: > 5000 nM
Compound 4 gave a limit, no number; the forecaster's own chance of this, stated with the estimate: 80%; the middle value lies beyond the limit too.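

Among these compounds, compound 3 and compound 4 each give only a limit in this assay and not a number, so no size can be read for the step between them, and compound 4 adds no new readable step. The compounds shown leave open whether any aryl group on the sulfonyl sulfur of the shared core would give a readable value, for all that they show is this: the limit of > 5000 nM in this assay, at which 4 of the 4 values shown sit.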